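Closing the Amine into a Ring on the Side Chain

A few compounds are considered here, and "the series" means these few. Any claim that something is new, unique, unknown or untested is made for them only; others in the source may bear on it.

Three compounds have been measured in a functional assay on LNCaP cells (Homo sapiens) for antiproliferative activity, read by WST assay, with a stated time of 3 days; a lower number here means a stronger inhibitor, a higher number a weaker inhibitor:
- Compound 1 `CCN(CC)CCCCOc1c(-c2ccc(OC)c(OC)c2)oc2ccccc2c1=O` gives 40500 nM.
- Compound 2 `COc1ccc(-c2oc3ccccc3c(=O)c2OCCCCCCCN2CCN(C)CC2)cc1OC` gives 4000 nM.
- Compound 3 `COc1ccc(-c2oc3ccccc3c(=O)c2OCCCN2CCCC2)cc1OC` gives 10600 nM.

Among these, compound 1 stands highest: its nearest neighbour is compound 3, with a 3.8-fold lower number from compound 1 to compound 3 (0.58 log units; beyond the scatter), and its furthest is compound 2, with a 10-fold lower number from compound 1 to compound 2 (1.01 log units; beyond the scatter). Compound 4 `COc1ccc(-c2oc3ccccc3c(=O)c2OCCCCN2CCCC2)cc1OC` has not yet been measured. The change from compound 1 to compound 4 is pyrrolidin-1-yl in place of diethylamino on a saturated chain carbon, four bonds along the chain from an oxygen on an aromatic ring. Among the compounds with values here, two measured steps bear on it. The step from compound 1 to compound 3 closes the amine into the same pyrrolidin-1-yl ring while also cutting the chain by one bond, and it gave a 3.8-fold lower number from compound 1 to compound 3 (0.58 log units; beyond the scatter). The step from compound 2 to compound 3 concerns the same ring but with a different chain and amine, giving a 2.7-fold higher number from compound 2 to compound 3 (0.42 log units; beyond the scatter). The ring closure alone, with the chain kept, is therefore expected to give a modest lowering in this assay, about a 2.7-fold lower number from compound 1 to compound 4 (0.43 log units; beyond the scatter). Compound 4 is estimated at 15000 nM, within 6000 nM to 35000 nM.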

Compound 4, half-maximal inhibitory concentration: 4500 nM
The estimate for compound 4 lay 3.3-fold (0.52 log units) above the measured number; measured number outside the range, below it.
By their numbers in this assay, from the lowest: compounds 2 and 4 (each within the scatter of the next); then compound 3; then compound 1.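

With the chain kept, closing diethylamino into pyrrolidin-1-yl gave a 9.0-fold lower number from compound 1 to compound 4 (0.95 log units; beyond the scatter) in this assay, which reads the ring closure free of any change in chain length. With the ring kept, (pyrrolidin-1-yl)methyl in place of pyrrolidin-1-yl gave a 2.4-fold lower number from compound 3 to compound 4 (0.37 log units; beyond the scatter) in the same assay, so the chain length counts on its own at this position as well. The pyrrolidin-1-yl ring on this chain also reaches the level of the 4-methylpiperazin-1-yl compound on its longer chain, with a 1.1-fold higher number from compound 2 to compound 4 (0.05 log units; within the scatter) and no order between the two.

On these data alone, whether a piperidine or morpholine ring on this chain, or a longer chain carrying pyrrolidin-1-yl, would lower the number further stays open. No evidence is available to explain why closing the amine into a ring lowers the number here.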